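Phenyl in place of methyl on compound 3

A few compounds are considered here, and "the series" means these few. Any claim that something is new, unique, unknown or untested is made for them only; others in the source may bear on it.

In a functional assay on BMEC cells (Bos taurus) for antiproliferative activity (a higher number here means a weaker inhibitor, a lower number a stronger inhibitor), compound 3 (`COc1cc(/C=C/Cc2cc(O)c3cc(C)sc3c2)cc(OC)c1OC`) stands at 840 nM as the second highest of three numbers, with compound 2 (`COc1cc(/C=C\Cc2cc(O)c3cc(C)sc3c2)cc(OC)c1OC`) lower at 23 nM and compound 1 (`COc1cc(/C=C/Cc2cc(O)c3ccsc3c2)cc(OC)c1OC`) higher at 38700 nM in the same series. Compound 4 (`COc1cc(/C=C/Cc2cc(O)c3cc(-c4ccccc4)sc3c2)cc(OC)c1OC`) carries phenyl in place of methyl on an aromatic carbon next to the ring sulfur (phenyl in place of methyl on an aromatic carbon). The step bearing most directly on this change sits on the same carbon: methyl in place of hydrogen gave a 46-fold lower number from compound 1 to compound 3 (1.66 log units; beyond the scatter) and so this carbon matters in the series. The other large step, a 37-fold higher number from compound 2 to compound 3 (1.56 log units; beyond the scatter) concerns only the double bond, as shown by the fact that compounds 2 and 3 differ only in the configuration as drawn for that pair. No group larger than methyl has been measured on this carbon, so the direction remains uncertain, but a moderate move to a higher number is expected. The expected change is a 3.0-fold higher number from compound 3 to compound 4 (0.47 log units; beyond the scatter) and would stay smaller than the step from hydrogen to methyl. In this assay the estimated value for compound 4 is 2500 nM with 400 nM to 15000 nM as the expected range.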

Compound 4, half-maximal inhibitory concentration: 38000 nM
For compound 4 the middle estimate is 15-fold (1.18 log units) below the measured one; the measured number lies above the stated range.
By their numbers in this assay, from the lowest: compound 2; then compound 3; then compounds 4 and 1 (each within the scatter of the next).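

In this assay, the aromatic carbon next to the ring sulfur does not accept just any group larger than hydrogen: phenyl in place of methyl gives a large loss (a 45-fold higher number from compound 3 to compound 4 (1.66 log units; beyond the scatter)). Phenyl in place of hydrogen gives no separable change (a 1.0-fold lower number from compound 1 to compound 4 (0.01 log units; within the scatter)), so among hydrogen, methyl and phenyl on this carbon, in compounds with the double bond drawn E, only methyl lowers the number, and the response does not follow group size in a steady way. Nothing at hand gives a reason for the loss with phenyl.

As far as these compounds go, whether ethyl, an amine or a carboxylic acid on this carbon would keep the number of compound 3 stays open. Also open, from the compounds shown here alone, is whether phenyl with the double bond drawn Z, as in compound 2, shows the same loss.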